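A few compounds are considered here, and "the series" means these few. Any claim that something is new, unique, unknown or untested is made for them only; others in the source may bear on it.

In an ADME assay (liver) for metabolic stability, with Liver microsome (Homo sapiens) as the target, read by LC-MS, using microsomes, with a stated time of 1 h, tested at 5 uM; on this read-out higher numbers stand for a more stable compound and lower numbers for a less stable compound:
compound 1 `Cc1nc(-c2ccccc2)c(C(=O)N2CCN(c3cccc(C#N)c3)CC2)o1` gives 8%
compound 2 `Cc1nc(-c2cccc(F)c2)c(C(=O)N2CCN(c3cc(Cl)cc(Cl)c3)CC2)o1` gives 75.9%

Among the compounds with values here, compound 1 stands lowest of the two numbers measured so far; its nearest neighbour is compound 2, which sits higher by a margin beyond the scatter. The two differ in more than one place, so their gap cannot be tied to a single change. Within the data shown here, no step between measured compounds differing in one place exists, and the move to compound 3 `COc1cc(OC)cc(N2CCN(C(=O)c3oc(C)nc3-c3ccccc3)CC2)c1` therefore rests on the structural change alone. That change is 3,5-dimethoxyphenyl in place of 3-cyanophenyl on an amine nitrogen in a ring; the 3,5-dimethoxyphenyl takes the place of the 3-cyanophenyl on the amine nitrogen in the ring. Nothing measured here shows what this swap does in this assay, so the working assumption is that compound 1 and compound 3 remain close. For compound 3 the expected step is a number 1 percentage points higher from compound 1 to compound 3 (within the scatter), meaning none beyond the scatter. Compound 3 is estimated at 9%, with a range from 1% to 28%.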

Compound 3, percent of the compound remaining: 15.8%
The estimate for compound 3 lay 6.8 percentage points below the measured number; low and high end bracket the measured number.
By their numbers in this assay, from the lowest: compounds 1 and 3 (each within the scatter of the next); then compound 2.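

In this assay, within the data shown here, the first comparison that differs in one place puts 3,5-dimethoxyphenyl in place of 3-cyanophenyl on the amine nitrogen in the ring and gives a number 7.8 percentage points higher from compound 1 to compound 3 (within the scatter). At this position, the read-out does not separate these two groups, even though they differ in their substituents and in their counts of heavy atoms and hydrogen-bond acceptors. Nothing available bears on the reason for this result.

The compounds shown do not settle whether the number for compound 2, 75.9%, goes with its dichlorophenyl group on the amine nitrogen, with its fluorine on the other phenyl, or with both together. Also open, from the compounds shown here alone, is how a pyridyl ring or a simple alkyl chain would read on the same amine nitrogen.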